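The compounds below may be only part of what the source reports. "The series", "measured", "known", "first", "only" and "open" are said of these compounds alone.

Working notes on the series. Within the data shown here, in a functional assay on CCRF-CEM cells (Homo sapiens) for inhibition, read by cell counting, with a stated time of 3 days (on this read-out lower numbers stand for stronger inhibition and higher numbers for weaker inhibition), compound 1 `C=C(Br)C(=O)Nc1cccc(-c2cn3nc(-c4ccc(OCC)cc4)sc3n2)c1` gives 1400 nM, the second highest of the three numbers measured so far. Compound 2 `C=C(Br)C(=O)Nc1cccc(-c2cn3c(-c4ccc(OC)cc4)csc3n2)c1` gives 500 nM and stands below it, while compound 3 `COc1ccc(-c2csc3nc(-c4cccc(N)c4)cn23)cc1` gives 6100 nM and stands above it. Compound 2 differs from compound 1 both in the shared core and in the group on the six-membered ring, so the gap between their two values cannot be assigned to either change alone.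

Among the measured compounds shown here, the only step between compounds that differ in one place is a 12-fold higher number from compound 2 to compound 3 (1.09 log units; beyond the scatter), the replacement of hydrogen for (1-bromoethenyl)carbonyl on a nitrogen on an aromatic ring. That step concerns the amide nitrogen, not the six-membered ring, and does not bear on the change examined here.

Compound 4 `C=C(Br)C(=O)Nc1cccc(-c2cn3nc(-c4ccc(F)cc4)sc3n2)c1` differs from compound 1 as follows: fluoro in place of ethoxy on an aromatic carbon. For the measured compounds named here, no measured step touches this position, so nothing supports a direction. The expectation is therefore a step within the scatter, no change at the digits printed from compound 1 to compound 4 (within the scatter), with the range widened for the absence of any guiding step. Compound 4 is estimated at 1400 nM in this assay, between 450 nM and 4500 nM.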

Compound 4, half-maximal inhibitory concentration: 830 nM
Compound 4: the middle estimate sits 1.7-fold (0.23 log units) above what was measured; the measured number falls inside the stated range.
By their numbers in this assay, from the lowest: compounds 2, 4 and 1 (each within the scatter of the next, the first and the last beyond it); then compound 3.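

In this assay, among these compounds, the group on the six-membered aromatic ring of carbon only, para to a large group, is varied on its own for the first time, and fluoro in place of ethoxy gives a 1.7-fold lower number from compound 1 to compound 4 (0.23 log units; within the scatter) on an unchanged core. Ethoxy, with its 3 heavy atoms and 1 hydrogen-bond acceptor, can therefore give way to a single fluorine atom with no hydrogen-bond acceptor and no change beyond the scatter, so this pair shows no dependence of the number on ethoxy at this position. Nothing available explains why this exchange leaves the number within the scatter.

With only ethoxy and fluoro compared at this position, the pair cannot show whether a larger change, such as an amine, a carboxylic acid or a longer alkoxy chain like butoxy, would move the number beyond the scatter. The compounds shown also leave open whether fluoro in place of ethoxy would give a similar step on the core of compound 2, or in the absence of the (1-bromoethenyl)carbonyl group.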